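Clearance notes: replacing 4-methylthiophen-2-yl in the series

The source may report more compounds than this note shows. Statements on the series, on what has been measured and on what is new or still open speak of the compounds shown alone.

Measured in an ADME assay (liver) for metabolic stability, with Liver microsome (Homo sapiens) as the target, using microsomes and NADPH, with a stated time of 30 min, tested at 1 uM; on this read-out higher numbers stand for fast clearance and lower numbers for slow clearance:
- compound 1 `Nc1ccc(S(=O)(=O)N2CCN(c3ncc(C(O)(C(F)(F)F)C(F)(F)F)cc3Br)CC2)cn1`: < 14 mL.min-1.g-1 (a limit of the assay)
- compound 2 `Cc1csc(-c2cc(C(O)(C(F)(F)F)C(F)(F)F)cnc2N2CCN(S(=O)(=O)c3ccc(N)nc3)CC2)c1`: 29 mL.min-1.g-1

For the measured compounds named here, compound 2 gives 29 mL.min-1.g-1, the only true number so far in this assay. The one other result, that of compound 1, is a limit of the assay.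

The next change leads to compound 3 `CS(=O)(=O)c1ccc(-c2cc(C(O)(C(F)(F)F)C(F)(F)F)cnc2N2CCN(S(=O)(=O)c3ccc(N)nc3)CC2)cc1`, with 4-(methylsulfonyl)phenyl in place of 4-methylthiophen-2-yl on an aromatic carbon.

Going by the values given here, the only measured step at this place is an at least 2.0-fold higher number from compound 1 to compound 2 (0.31 log units; beyond the scatter), which brought in the group that now leaves. On that step alone, its removal is expected to give back part of the rise, although the entering group differs from bromo and the guide is loose. The expected step is a 1.7-fold lower number from compound 2 to compound 3 (0.23 log units; within the scatter), a modest one towards slower clearance, and a result reported only as a limit is possible.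

The estimate for compound 3 is 17 mL.min-1.g-1, with an expected range of 10 mL.min-1.g-1 to 30 mL.min-1.g-1.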

Compound 3, intrinsic clearance in microsomes: 32 mL.min-1.g-1
For compound 3 the middle estimate is 1.9-fold (0.27 log units) below the measured one; measured number above the stated range.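

In this assay, 4-(methylsulfonyl)phenyl in place of 4-methylthiophen-2-yl gives a 1.1-fold higher number from compound 2 to compound 3 (0.04 log units; within the scatter), so these two aromatic groups do not separate at this position, although they differ in ring type and heavy-atom count. Against bromo, the new group gives an at least 2.2-fold higher number from compound 1 to compound 3 (0.35 log units; beyond the scatter), so the step beyond the scatter seen with 4-methylthiophen-2-yl is now also seen with a six-membered aromatic ring of carbon only. From the compounds shown here alone, the true size of both steps from compound 1 stays unknown, as compound 1 is held only at a limit of the assay: the limit of < 14 mL.min-1.g-1 in this assay, at which 1 of the 3 values shown sits.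

A morpholine, a short alkyl chain or a nitrile at this place would test whether the higher number needs an aromatic ring at all. Also open, going by these compounds, is whether a carboxylic acid in place of the methylsulfonyl group would leave the number unchanged.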